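Swapping a Ring for a Chain on the Amine Nitrogen

This account rests on a few compounds, and the source may have more. Where it says the series, first, only, none or still open, it means among the compounds named here.

Compound 1 `CCCNC(=C\C(=O)/C=C/c1ccc(O)c(OC)c1)/C=C/c1ccc(O)c(OC)c1` gave 97% in a functional assay on Caco-2 cells (Homo sapiens), read by fluorescence, tested at 1 uM; a higher number here means a weaker effect of the compound at the concentration tested, a lower number a stronger effect. Compound 2 `C=CCNC(=C\C(=O)/C=C/c1ccc(O)c(OC)c1)/C=C/c1ccc(O)c(OC)c1` gave 89% in this assay. Compound 3 `COc1cc(/C=C/C(=O)/C=C(/C=C/c2ccc(O)c(OC)c2)NC2CCCCC2)ccc1O` gave 88% in this assay.

All three compounds share one core and differ only in the group on the amine nitrogen. Their numbers sit close together: from compound 1 to compound 2 the reading moved by a number 8 percentage points lower from compound 1 to compound 2 (within the scatter), from compound 1 to compound 3 by a number 9 percentage points lower from compound 1 to compound 3 (within the scatter), and from compound 2 to compound 3 by a number 1 percentage points lower from compound 2 to compound 3 (within the scatter). Compound 3 thus stands within the scatter of both others, and none of the three can be called more or less effective than the rest.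

Compound 4 `CCCCNC(=C\C(=O)/C=C/c1ccc(O)c(OC)c1)/C=C/c1ccc(O)c(OC)c1` has not yet been measured. It differs from compound 3 by butyl in place of cyclohexyl on an amine nitrogen. Among the compounds with values here, the step that bears most directly on this change is the one from compound 1 to compound 3, where propyl gave way to cyclohexyl and the reading shifted only by a number 9 percentage points lower from compound 1 to compound 3 (within the scatter); the step from compound 2 to compound 3, a number 1 percentage points lower from compound 2 to compound 3 (within the scatter), points the same way. Returning from the ring to a chain one carbon longer than propyl is therefore expected to move the number by a number 5 percentage points higher from compound 3 to compound 4 (within the scatter), a step within the scatter. Compound 4 is expected to give about 93% in this assay, somewhere between 83% and 100%.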

Compound 4, a percentage reported as activity, at one concentration (the size of the read-out at that concentration, not a potency): 91%
Compound 4: the middle estimate sits 2 percentage points above what was measured, within the range that was stated.
By their numbers in this assay, from the lowest: compounds 3, 2, 4 and 1 (each within the scatter of the next).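

The step of a number 3 percentage points higher from compound 3 to compound 4 (within the scatter) in this assay shows that opening the ring into a butyl chain on the amine nitrogen leaves the reading within the scatter, so at this position the six-membered ring shows no measurable advantage over an open chain. The chains compared with one another tell the same story: the step of a number 2 percentage points higher from compound 2 to compound 4 (within the scatter) sets butyl against allyl, the step of a number 6 percentage points lower from compound 1 to compound 4 (within the scatter) sets butyl against propyl, and thus neither the added chain carbon nor the double bond of allyl separates these compounds in this read-out. All four compounds now count as equal here, whether the group is straight, unsaturated or cyclic, and no measurement on hand explains the readings.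

Every group shown on this nitrogen is built of carbon and hydrogen alone, which leaves open whether a phenyl ring, a chain ending in a hydroxyl group or an amine, or a carboxylic acid would take the number beyond the scatter. The readings also come from a single concentration, so any difference in potency among these four compounds remains unknown.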